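A few compounds are considered here, and "the series" means these few. Any claim that something is new, unique, unknown or untested is made for them only; others in the source may bear on it.

In a functional assay on A549 cells (Homo sapiens) for inhibition, read by MTT assay, with a stated time of 48 h (a lower number here means a stronger inhibitor, a higher number a weaker inhibitor), three compounds have been measured so far. Compound 1 `COc1ccc(CNC(=O)/C=C/c2coc3cc(O)ccc3c2=O)cc1` gives > 100000 nM, which is a limit of the assay and not a number. Compound 2 `COc1ccc2c(=O)c(/C=C/C(=O)NCc3ccccc3)coc2c1` gives 11800 nM. Compound 3 `COc1ccc2c(=O)c(/C=C/C(=O)Nc3ccccc3Cl)coc2c1` gives 29900 nM, the higher of the two numerical values, and compound 2 is its nearest neighbour.

The next compound to be tested in this assay is compound 4 `COc1ccc2c(=O)c(/C=C/C(=O)NCc3ccc(F)cc3)coc2c1`. It carries 4-fluorobenzyl in place of the 2-chlorophenyl of compound 3, on an amide-type nitrogen whose other neighbour is the carbonyl carbon: 4-fluorobenzyl in place of 2-chlorophenyl on an amide-type nitrogen.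

Among the measured compounds shown here, one measured step bears on this change: a 2.5-fold higher number from compound 2 to compound 3 (0.40 log units; beyond the scatter), in which 2-chlorophenyl took the place of benzyl on the same kind of nitrogen. For the measured compounds named here, compound 4 goes back from 2-chlorophenyl to a benzyl group, now bearing fluorine, and no measured step covers that fluorine. A modest change in the opposite direction is therefore expected, of about the size of the step from compound 2 to compound 3, and the estimate is a 2.3-fold lower number from compound 3 to compound 4 (0.36 log units; beyond the scatter). In this assay, compound 4 is estimated at 13000 nM, with an expected range from 5000 nM to 35000 nM.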

Compound 4, half-maximal inhibitory concentration: > 100000 nM
Compound 4 was reported as a limit (the forecaster's own chance of this, stated with the estimate: 5%); middle value at least 7.6-fold (0.88 log units) away from the limit.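

The result for compound 4 in this assay is a limit of the assay and not a number, and it is the second such limit among the compounds shown: the limit of > 100000 nM in this assay, at which 2 of the 4 values shown sit.

Fluoro in place of hydrogen on an aromatic carbon, a single change on the benzyl group, gives an at least 8.4-fold higher number from compound 2 to compound 4 (0.92 log units; beyond the scatter), a step larger than the one numerical step seen earlier, so a small change on this group can decide whether a number is obtained at all. The exchange of 2-chlorophenyl for 4-fluorobenzyl on the amide-type nitrogen gives an at least 3.3-fold higher number from compound 3 to compound 4 (0.52 log units; beyond the scatter), which shows that the earlier order, with the benzyl compound 2 giving the lower number, does not hold for every benzyl group.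

Both new steps have only a lower bound, and the compounds shown do not tell how far compound 4 lies beyond its limit. They also leave open whether the loss follows fluorine itself or any group at that place on the benzyl ring, as a 4-chlorobenzyl or 4-methylbenzyl group would show, and whether a longer chain such as phenethyl on the same nitrogen would give a number at all.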